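Hydroxy replacement on compound 2: working notes

The source may report more compounds than this note shows. Statements on the series, on what has been measured and on what is new or still open speak of the compounds shown alone.

- compound 1 `CNC(=O)[C@@H](NC(=O)[C@](O)(CCCN(Cc1ccc(Br)cc1)NC(=O)[C@@H](NC(=O)OC)C(C)(C)C)Cc1ccccc1)C(C)(C)C`: > 10000 nM
- compound 2 `CNC(=O)[C@@H](NC(=O)[C@@](O)(CCCN(Cc1ccc(Br)cc1)NC(=O)[C@@H](NC(=O)OC)C(C)(C)C)Cc1ccccc1)C(C)(C)C`: > 10000 nM

In an ADME assay on MT4 cells (Homo sapiens) for cytotoxicity, read by XTT assay, with a stated time of 5 days (on this read-out lower numbers stand for higher toxicity in this test and higher numbers for lower toxicity in this test), compound 2 gives > 10000 nM, which is a limit and not a number. Compound 1 gives > 10000 nM, also a limit. Both compounds therefore stand at the limit of > 10000 nM in this assay, at which 2 of the 2 values shown sit, and no ranking of them is possible.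

The change to compound 3 `CNC(=O)[C@@H](NC(=O)[C@@](CCCN(Cc1ccc(Br)cc1)NC(=O)[C@@H](NC(=O)OC)C(C)(C)C)(Cc1ccccc1)[Si](C)(C)C(C)(C)C)C(C)(C)C` is a group of 7 heavy atoms (6 carbon, 1 silicon; no ring) in place of one oxygen atom, on a saturated chain carbon bound to a carbonyl carbon and two saturated chain carbons.

Among the measured compounds shown here, the only measured step is a step that the two limits leave unreadable from compound 1 to compound 2. It concerns (the fact that compounds 1 and 2 differ only in the configuration as drawn), so it does not cover a replacement of this kind and gives no size to carry over. No direction can be read from the data in this assay. The expected step is a number no higher from compound 2 to compound 3 (the limit leaves the size open), an estimate held loosely. For compound 3 the estimated value is 10000 nM, expected to lie between 3000 nM and 30000 nM.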

Compound 3, half-maximal cytotoxic concentration: > 10000 nM
Compound 3 was reported as a limit (the forecaster's own chance of this, stated with the estimate: 60%); the middle value lies on the limit itself.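

Among the compounds shown here, no step from compound 2 to compound 3 can be read in this assay, as the result for compound 3 is a limit and not a number: the limit of > 10000 nM in this assay, at which 3 of the 3 values shown sit.

The compounds shown leave open whether the group of 7 heavy atoms in place of hydroxy changes this read-out at all, and in which direction.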